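This account rests on a few compounds, and the source may have more. Where it says the series, first, only, none or still open, it means among the compounds named here.

Compounds measured so far:
compound 1 `CC(C)COc1ccc2c(Cl)ccnc2c1` gives 3190 nM
compound 2 `CC(C)Oc1ccc2c(Cl)ccnc2c1` gives 3060 nM
compound 3 `CCCCOc1ccc2c(Cl)ccnc2c1` gives 4130 nM

These three numbers come from a functional assay on SK-OV-3 cells (Homo sapiens) for cytotoxicity, read by MTT assay, with a stated time of 48 h; a higher number here means a weaker inhibitor, a lower number a stronger inhibitor. Compound 3 has the highest number of the three, yet its nearest neighbour is compound 1, a 1.3-fold higher number from compound 1 to compound 3 (0.11 log units; within the scatter), and its furthest is compound 2, a 1.3-fold higher number from compound 2 to compound 3 (0.13 log units; within the scatter); both gaps lie within the scatter, so the three alkoxy compounds cannot be ordered against one another. The step from compound 1 to compound 2, a 1.0-fold lower number from compound 1 to compound 2 (0.02 log units; within the scatter), likewise shows that isobutyl and isopropyl are indistinguishable here.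

Compound 4 `Clc1ccnc2cc(OCCc3ccccc3)ccc12` is not yet measured. It differs from compound 3 in this way: phenyl in place of ethyl on a saturated chain carbon, two bonds along the chain from an oxygen on an aromatic ring. For the measured compounds named here, none of the measured steps involves a ring entering the chain; they only compare alkyl groups of different shape, and each of those, a 1.3-fold higher number from compound 2 to compound 3 (0.13 log units; within the scatter) and a 1.3-fold higher number from compound 1 to compound 3 (0.11 log units; within the scatter), stayed within the scatter. The data therefore give no ground for expecting a step beyond the scatter in this assay, and the expected step from compound 3 to compound 4 is a 1.2-fold lower number from compound 3 to compound 4 (0.07 log units; within the scatter). Compound 4 is estimated at 3500 nM, with a range of 1500 nM to 8500 nM.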

Compound 4, half-maximal inhibitory concentration: 2010 nM
Beside the measured number, compound 4's estimate is 1.7-fold (0.24 log units) above it; measured number inside the range.
By their numbers in this assay, from the lowest: compounds 4, 2, 1 and 3 (each within the scatter of the next, the first and the last beyond it).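

In this assay, for the compounds shown here, the change from ethyl to phenyl (a 2.1-fold lower number from compound 3 to compound 4 (0.31 log units; beyond the scatter)) is the first step to pass beyond the scatter, whereas every step among the alkyl groups on the oxygen stayed within it. It shows that a six-membered aromatic ring of carbon only can stand on the saturated chain, two bonds along the chain from the oxygen on the aromatic ring, and that the number then falls rather than rises, though the step is modest and compound 4 remains within the scatter of compound 2, the next number in the series. No measurement at hand accounts for this step.

The compounds shown leave open whether the drop belongs to the phenyl ring itself or simply to the greater length of the group, which a longer unbranched chain such as hexyl would help to separate. They also leave open how a phenyl ring carrying a substituent such as fluorine or methoxy, a saturated cyclohexyl ring, or a chain ending in an amine would behave at this place.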